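This account rests on a few compounds, and the source may have more. Where it says the series, first, only, none or still open, it means among the compounds named here.

Within the data shown here, in a functional assay on HCC 2998 cells (Homo sapiens) for cytotoxicity, read by sulforhodamine B assay, with a stated time of 48 h (a higher number here means that more compound is tolerated, a lower number that less compound is tolerated), compound 1 `ClCc1cccc(Cn2cnc3ncnc(Cl)c32)c1` gives 40700 nM, the highest of the two numbers measured so far. Compound 2 `ClCc1ccc(Cn2cnc3nc(Cl)nc(Cl)c32)cc1` gives 7070 nM in this assay, a considerably lower number, but compound 2 differs from compound 1 in more than one place, so the two values only show that a second chloro group combined with a different arrangement on the benzyl ring went together with less compound being tolerated. Compound 3 `ClCc1cccc(Cn2cnc3nc(Cl)nc(Cl)c32)c1` differs from compound 1 in a single way: chloro in place of hydrogen on an aromatic carbon, so that the shared core now carries two chloro groups instead of one, while the benzyl part is kept exactly as in compound 1. Among the measured compounds shown here, no single-change step has been measured here to anchor this move. The expectation is that the second chloro group lowers the number, as the doubly chlorinated compound 2 does, though with a sizable uncertainty about how far. The step from compound 1 to compound 3 is estimated at a 3.4-fold lower number from compound 1 to compound 3 (0.53 log units; beyond the scatter). Compound 3 is therefore expected to give about 12000 nM in this assay, somewhere in the range from 4000 nM to 35000 nM.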

Compound 3, concentration lethal to 50% of the cells: 5750 nM
The estimate for compound 3 lay 2.1-fold (0.32 log units) above the measured number; the measured number falls inside the stated range.
By their numbers in this assay, from the lowest: compounds 3 and 2 (each within the scatter of the next); then compound 1.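

In this assay, placing a chloro group on the aromatic carbon between two ring nitrogen atoms comes with a 7.1-fold lower number from compound 1 to compound 3 (0.85 log units; beyond the scatter) and this is the first step shown that changes one place only, so the lower number can now be tied to this single atom on the shared core rather than to a mix of changes. Compound 2 and compound 3 carry the same doubly chlorinated core and differ only in the arrangement on the benzyl ring, and their values lie within the usual scatter of each other, so this pair shows no clear difference from that arrangement. Nothing on hand explains how the added chloro group acts on these cells.

Still open, from the compounds shown here alone, is whether this response belongs to chlorine in particular, as an amine, a methoxy group or a fluoro group on the same carbon would give the comparison needed to tell. Every compound shown also keeps its chloromethyl group on the benzyl ring, so what that group contributes remains unknown, and a plain methyl or hydroxymethyl group there would be the direct test.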